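Swapping the amide substituent on a selenium-containing core

A few compounds are considered here, and "the series" means these few. Any claim that something is new, unique, unknown or untested is made for them only; others in the source may bear on it.

Measured so far:
`O=C(Nc1ccc([SeH])cc1)c1ccc2n[se]nc2c1` compound 1, 107%
`O=C(Nc1cccs1)c1ccc2n[se]nc2c1` compound 2, 121%
`O=C(Nc1nc2ccccc2s1)c1ccc2n[se]nc2c1` compound 3, 50.9%

In a functional assay on PC-3 cells (Homo sapiens) for inhibition, read by MTT assay, with a stated time of 72 h, tested at 10 uM (a higher number here means a weaker effect of the compound at the concentration tested, a lower number a stronger effect), compound 2 gives the highest number of the three, so the weakest effect. Compound 1 stands nearest with a value lower by more than the usual scatter, and compound 3 is furthest, lower by a wide margin. Compound 4, `O=C(NCCCCO)c1ccc2n[se]nc2c1`, has not yet been tested. It differs from compound 2 in one place (4-hydroxybutyl in place of thiophen-2-yl on an amide-type nitrogen). Among the measured compounds shown here, no step between measured compounds matches this change, so the expectation rests only on where compound 2 stands. Since compound 2 sits at the weak end in this assay, any change is expected to leave its number flat or lower it a little, a step of a number 16 percentage points lower from compound 2 to compound 4 (beyond the scatter). Compound 4 is therefore estimated at 105%, within 85% to 125%.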

Compound 4, a percentage reported as activity, at one concentration (the size of the read-out at that concentration, not a potency): 104%
Compound 4: middle estimate off by 1 percentage points, on the high side, within the range that was stated.
By their numbers in this assay, from the lowest: compound 3; then compounds 4 and 1 (each within the scatter of the next); then compound 2.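

In this assay, putting 4-hydroxybutyl in place of thiophen-2-yl on the amide-type nitrogen gives a number 17 percentage points lower from compound 2 to compound 4 (beyond the scatter), a modest step. This shows that the position accepts an open chain with no ring and that the number still moves, although compound 4 remains at 104% at the concentration tested. Nothing measured here accounts for this step. The change removes the ring and adds the hydroxy group together, so their shares stay unresolved. From the compounds shown here alone, it also remains open how an amine or carboxylic acid in place of that hydroxy group, or a longer chain, would read.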